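The source may hold more compounds than are shown below. What is called first, only, known or untested is meant among the compounds shown, and "the series" means these compounds.

Measured so far:
compound 1 `CCCCCCCCCCCCCCCCOP(=O)(O)OCCSC(=S)N1CCCCCC1`: > 100000 nM
compound 2 `CCCCCCCCOP(=O)(O)OCCSC(=S)N1CCCCCC1`: 27000 nM
compound 3 `CCCCCCOP(=O)(O)OCCSC(=S)N1CCCCCC1`: 17200 nM

In a functional assay on MDA-MB-231 cells (Homo sapiens) for inhibition, read by MTT assay, with stated times of 18 h and 4 h (a higher number here means a weaker inhibitor, a lower number a stronger inhibitor), compound 1 gives only a limit, > 100000 nM, and not a number. It therefore gives a poor fix on any step that starts from it.

The next compound is compound 4 `CCCCCCCCCCCCCCCCOP(=O)(O)OCCSC(=S)N1CCCCC1`, which keeps the chain of compound 1 and changes the ring: piperidin-1-yl in place of azepan-1-yl on a thiocarbonyl carbon. In words, piperidin-1-yl replaces azepan-1-yl on a thiocarbonyl carbon.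

For the measured compounds named here, no measured step changes this ring. All three measured steps shorten the chain: an at least 3.7-fold lower number from compound 1 to compound 2 (0.56 log units; beyond the scatter), an at least 5.8-fold lower number from compound 1 to compound 3 (0.76 log units; beyond the scatter) and a 1.6-fold lower number from compound 2 to compound 3 (0.20 log units; within the scatter). The first two lie beyond the scatter and the third within it. These steps give no size for the ring change, but they do tie the long chain of compound 1 to the weak end of the series at > 100000 nM.

No step beyond the scatter is therefore expected in this assay, and a limit may well be reported again. The estimated change is a number no higher from compound 1 to compound 4 (the limit leaves the size open). For compound 4 the expected value is 100000 nM, with an estimated range of 30000 nM to 300000 nM.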

Compound 4, half-maximal inhibitory concentration: 100000 nM
Beside the measured number, compound 4's estimate shows no gap at the digits printed; the range from low to high includes it.
By their numbers in this assay, from the lowest: compounds 3 and 2 (each within the scatter of the next); then compound 4.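

In this assay, for the compounds shown here, the ring on the thiocarbonyl carbon changes for the first time, with piperidin-1-yl in place of azepan-1-yl, and the outcome is a number no higher from compound 1 to compound 4 (the limit leaves the size open). The size of this ring change cannot be read because compound 1 carries a limit and not a number: the limit of > 100000 nM in this assay, at which 1 of the 4 values shown sits. With the long chain kept, the piperidin-1-yl ring does give a fixed value, with compound 4 at 100000 nM.

On these data alone, whether piperidin-1-yl alters the number on the shorter chains of compound 2 and compound 3 remains open. Also open, as far as these compounds go, is how this assay reads when the thiocarbonyl carbon carries a morpholin-4-yl ring, a piperazin-1-yl ring or an open-chain diethylamino group.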